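This account rests on a few compounds, and the source may have more. Where it says the series, first, only, none or still open, it means among the compounds named here.

Of the compounds shown here, three that share one core have been measured in a functional assay on HSC-4 cells (Homo sapiens) for cytotoxicity, with a stated time of 24 h; a higher number here means that more compound is tolerated, a lower number that less compound is tolerated. Compound 1 `O=C1/C(=C/c2ccccc2)CCC/C1=C\c1cccc([N+](=O)[O-])c1` gives 2400 nM, compound 2 `O=C1/C(=C/c2ccccc2)CCC/C1=C\c1ccc([N+](=O)[O-])cc1` gives 9200 nM, and compound 3 `O=C1/C(=C/c2ccc(F)cc2)CCC/C1=C\c1ccc([N+](=O)[O-])cc1` gives 15000 nM. Compound 3 cannot be told apart from compound 2 on these numbers, while compound 1 stands clearly lower than compound 3.

The next compound to consider is compound 4 `CN(C)c1ccc(/C=C2\CCC/C(=C\c3ccc([N+](=O)[O-])cc3)C2=O)cc1`. It keeps the core of compound 3 and carries dimethylamino in place of fluoro on an aromatic carbon, para to a large group (dimethylamino in place of fluoro on an aromatic carbon). Within the data shown here, only one measured step touches this place: a 1.6-fold higher number from compound 2 to compound 3 (0.21 log units; within the scatter), where fluoro replaced hydrogen on an aromatic carbon. Among the measured compounds shown here, that step is small, but it offers only weak guidance, since no measured compound carries dimethylamino and the group entering is larger than either hydrogen or fluoro.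

With so little to go on, no change beyond the scatter is expected in this assay, although the uncertainty runs in both directions. The expected step is a 1.5-fold lower number from compound 3 to compound 4 (0.18 log units; within the scatter). For compound 4 the estimated value is 10000 nM, with an expected range from 3000 nM to 30000 nM.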

Compound 4, half-maximal cytotoxic concentration: > 400000 nM
Compound 4 gave a limit, no number; the forecaster's own chance of this, stated with the estimate: 5%; at least 40-fold (1.60 log units) between middle value and limit.
By their numbers in this assay, from the lowest: compound 1; then compounds 2 and 3 (each within the scatter of the next). At a limit, above all of these: compound 4.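

In this assay, this aromatic carbon looked like a place where changes matter little, since fluoro in place of hydrogen gave only a 1.6-fold higher number from compound 2 to compound 3 (0.21 log units; within the scatter), but dimethylamino at the same place gives an at least 26-fold higher number from compound 3 to compound 4 (1.42 log units; beyond the scatter) and, set against hydrogen, an at least 43-fold higher number from compound 2 to compound 4 (1.63 log units; beyond the scatter). For compound 4 the result is a limit and not a number: the limit of > 400000 nM in this assay, at which 1 of the 4 values shown sits. The position is therefore not indifferent to what it carries: hydrogen and fluoro cannot be told apart here, whereas dimethylamino separates compound 4 clearly from both, by a margin known only as a minimum.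

With only hydrogen, fluoro and dimethylamino at this place, the compounds shown leave open whether a step of this size belongs to dimethylamino alone or would also appear with a primary amine, a methoxy group or an ethyl chain. They also leave open whether dimethylamino would bring the same large step in compound 1, which differs from compound 2 in where its nitro group sits on the ring.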